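A few compounds are considered here, and "the series" means these few. Any claim that something is new, unique, unknown or untested is made for them only; others in the source may bear on it.

This account follows a single structural change within a small set of closely related compounds, all tested in a functional assay on MOLT-4 cells (Homo sapiens) for cytotoxicity, read by sulforhodamine B assay, with a stated time of 48 h; on this read-out higher numbers stand for weaker inhibition of growth and lower numbers for stronger inhibition of growth. Compound 1, `ClCc1cccc(Cn2cnc3nc(Cl)nc(Cl)c32)c1`, gives 1040 nM in this assay. Compound 2, `ClCc1ccccc1Cn1cnc2nc(Cl)nc(Cl)c21`, gives 1340 nM in this assay. Of the two numbers available, compound 1 has the lowest, but its nearest neighbour, compound 2, sits within the scatter of the method, so the two cannot be told apart in strength. A third relative, compound 3, `ClCc1ccc(Cn2cnc3ncnc(Cl)c32)cc1`, was also prepared, yet in this assay compound 3 is recorded only as "not determined" (no result reported), so no number is available for it.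

The step of interest leads from compound 1 to compound 4, `ClCc1cccc(Cn2cnc3ncnc(Cl)c32)c1`. The difference between the two structures is hydrogen in place of chloro on an aromatic carbon. For the measured compounds named here, no step between two measured compounds is available here, so there is no direct precedent within the set for how such a swap of a chloro group for hydrogen shifts the numbers. In this assay the expected step is a small rise in the number, leaning toward weaker inhibition of growth, or no step beyond the scatter at all. Compound 4 is therefore estimated to give about 2000 nM, with a likely range from 700 nM to 6000 nM. The shift that this estimate implies is a 1.9-fold higher number from compound 1 to compound 4 (0.28 log units; within the scatter).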

Compound 4, concentration for 50% growth inhibition: 10700 nM
Estimate against measurement, compound 4: 5.4-fold (0.73 log units) below; measured number outside the range, above it.
By their numbers in this assay, from the lowest: compounds 1 and 2 (each within the scatter of the next); then compound 4.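

In this assay, the chloro group on the aromatic carbon between two ring nitrogen atoms clearly matters: with hydrogen in its place, there is a 10-fold higher number from compound 1 to compound 4 (1.01 log units; beyond the scatter), which means much weaker inhibition of growth. The two compounds with numbers before this one, compound 1 and compound 2, both carry this chloro group, so they could say nothing about this position, whereas this single pair shows that the position responds strongly to a change. No measurement at hand explains why removing this one atom has so large an effect.

Going by these compounds, what remains open is whether the chloro group itself is needed or whether other groups on this carbon would serve as well, such as fluoro, bromo, methyl, methoxy or an amine. This is also only one pair, with the chloromethyl group in one place on the benzyl ring, so the compounds shown cannot tell whether the same swap would have a step of similar size with the chloromethyl group placed elsewhere on that ring.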